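From pyrimidin-2-yl to pyridin-2-yl on a sulfonamide nitrogen

A few compounds are considered here, and "the series" means these few. Any claim that something is new, unique, unknown or untested is made for them only; others in the source may bear on it.

In a functional assay on NCI-H460 cells (Homo sapiens) for antiproliferative activity, read by sulforhodamine B assay, with a stated time of 72 h (a higher number here means a weaker inhibitor, a lower number a stronger inhibitor), compound 1 (`O=C1CS/C(=N/Nc2nncc3ccccc23)N1c1ccccc1`) gives 30 nM and compound 2 (`O=S(=O)(Nc1ncccn1)c1ccc(Nc2nncc3ccccc23)cc1`) gives 33 nM as its half-maximal inhibitory concentration. Compound 2 thus sits within the usual scatter of compound 1, and neither can be ranked above the other. Compound 3 (`O=S(=O)(Nc1ccccn1)c1ccc(Nc2nncc3ccccc23)cc1`) differs from compound 2 in one place, with pyridin-2-yl in place of pyrimidin-2-yl on a sulfonamide nitrogen. For the measured compounds named here, no two measured compounds differ in just one place, so the data hold no step to borrow for this change. With compound 2 at 33 nM as the only close reference, no step beyond the scatter is expected in this assay, in either direction. The expected change is a 1.2-fold higher number from compound 2 to compound 3 (0.08 log units; within the scatter) and it stays small. Compound 3 is estimated at 40 nM with an expected range from 13 nM to 120 nM in this measurement.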

Compound 3, half-maximal inhibitory concentration: 43 nM
Beside the measured number, compound 3's estimate is 1.1-fold (0.03 log units) below it, within the range that was stated.
By their numbers in this assay, from the lowest: compounds 1, 2 and 3 (each within the scatter of the next).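

In this assay the sulfonamide nitrogen now has its first readable one-place step, and that step is a 1.3-fold higher number from compound 2 to compound 3 (0.11 log units; within the scatter). Within this pair, the ring on that nitrogen can therefore go from pyrimidin-2-yl, with 2 hetero atoms and 2 hydrogen-bond acceptors, to pyridin-2-yl, with 1 of each, without a change that can be told from the scatter. Nothing available explains why the two compounds read alike.

The compounds shown leave open whether this tolerance extends to a phenyl ring with no ring nitrogen, a small methyl group, or a bare hydrogen on the sulfonamide nitrogen. They also leave open whether a five-membered ring such as thiazol-2-yl would keep the number within the scatter of compound 2.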